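The compounds below may be only part of what the source reports. "The series", "measured", "known", "first", "only" and "open" are said of these compounds alone.

Compound 1 `CC(C)n1ccnc1/N=C(\N)Nc1ccc(Cl)c(Cl)c1` carries an isopropyl group on its core; in an in vitro ADME assay on microsomes from liver (Mus musculus) for metabolic stability, read by LC-MS, tested at 1 uM (a higher number here means that the compound lasts longer, a lower number that the compound disappears faster), compound 1 gives 0.462 h. Compound 2 `CC(C)(C)n1ccnc1/N=C(\N)Nc1ccc(Cl)c(Cl)c1` differs from it by methyl in place of hydrogen on a saturated chain carbon bound to an aromatic nitrogen and two saturated chain carbons; in this assay compound 2 gives 0.8 h, which is a 1.7-fold higher number from compound 1 to compound 2 (0.24 log units; within the scatter). Compound 3 `CC(C)n1ccnc1/N=C(/NC(=O)C(C)(C)C)Nc1ccc(Cl)c(Cl)c1` is built on another core, and the difference between the two cores is not broken down here. In this assay compound 3 reaches only a limit of the assay, > 1 h, so no number is known for it. That limit is the limit of > 1 h in this assay, at which 1 of the 3 values shown sits. Going by the values given here, compound 4 `CC(C)(C)C(=O)N/C(=N/c1nccn1C(C)(C)C)Nc1ccc(Cl)c(Cl)c1` has not yet been measured; it differs from compound 3 by methyl in place of hydrogen on a saturated chain carbon bound to an aromatic nitrogen and two saturated chain carbons, the same change as the one from compound 1 to compound 2, made at a place described in the same words. Because a 1.7-fold higher number from compound 1 to compound 2 (0.24 log units; within the scatter) remained within the scatter, the step from compound 3 to compound 4 is expected to be small as well, a step that the limit leaves unreadable from compound 3 to compound 4. Compound 4 is therefore estimated to give about 1.5 h, somewhere between 0.7 h and 3 h, and will quite possibly again be reported only as a limit.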

Compound 4, half-life: > 1 h
Compound 4: a limit, no number; the forecaster's own chance of this, stated with the estimate: 65%; the middle value is on the limit's open side.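

In this assay compound 4 gives > 1 h, which is a limit of the assay and not a number. Going by these compounds alone, compound 3 sits at the same kind of limit, so no step from compound 3 to compound 4 can be read: the limit of > 1 h in this assay, at which 2 of the 4 values shown sit.

The compounds shown leave open how long compound 3 and compound 4 actually last, and whether isopropyl to tert-butyl changes their half-life at all.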